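The compounds below may be only part of what the source reports. "The series", "measured", "known", "first", "only" and "open" are said of these compounds alone.

In an assay on Sf9 cells for inhibition of protein deacetylase HDAC6 (Homo sapiens), read by fluorescence, with a stated time of 40 min, tested at 100 nM (on this read-out lower numbers stand for less inhibition and higher numbers for more inhibition at the one concentration tested (going by the name of the read-out)), compound 2 `Cc1cccc(-n2nc(-c3ccccc3)nc2CNc2ccc(C(=O)NO)cc2)c1` gives 66%. Among the compounds with values here, only one other compound has been measured alongside it: compound 1 `COc1ccc(-n2nc(-c3ccccc3)nc2CNc2ccc(C(=O)NO)cc2)cc1`, which in this assay gives 63.4%. Within the data shown here, the single step connecting the two, a number 2.6 percentage points higher from compound 1 to compound 2 (within the scatter), lies within the scatter, so compound 2 stands at a number that cannot be told apart from that of compound 1 on this read-out.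

Compound 3 `Cc1cc(C)cc(-n2nc(-c3ccccc3)nc2CNc2ccc(C(=O)NO)cc2)c1` differs from compound 2 by methyl in place of hydrogen on an aromatic carbon. Among the measured compounds shown here, the only measured step that bears on this, a number 2.6 percentage points higher from compound 1 to compound 2 (within the scatter), also altered the substituent on the same six-membered ring, exchanging one small aryl group for another, and it produced no change beyond the scatter. That step is a different exchange from the present one, so it speaks only loosely to adding a second methyl group, but nothing in the two numbers at hand points to a large movement in either direction.

Compound 3 is therefore expected to show a step of no change at the digits printed from compound 2 to compound 3 (within the scatter) in this assay, that is, none beyond the scatter. The estimate for compound 3 is 66%, with a range from 50% to 80%.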

Compound 3, a percentage reported as inhibition, at one concentration (the size of the read-out at that concentration, not a potency): 49.8%
Estimate against measurement, compound 3: 16.2 percentage points above, outside the stated range (below it).
By their numbers in this assay, from the lowest: compound 3; then compounds 1 and 2 (each within the scatter of the next).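

In this assay, the step from 3-methylphenyl to 3,5-dimethylphenyl is the first shown here to move the number beyond the scatter (a number 16.2 percentage points lower from compound 2 to compound 3 (beyond the scatter)). This means that the aryl group on the aromatic nitrogen is not indifferent to change: the earlier exchange stayed within the scatter (a number 2.6 percentage points higher from compound 1 to compound 2 (within the scatter)), whereas adding one methyl group on an aromatic carbon, meta to a large group and meta to a methyl group, lowers the read-out, and the comparison with the 4-methoxyphenyl compound points the same way (a number 13.6 percentage points lower from compound 1 to compound 3 (beyond the scatter)). No measurement at hand offers a reason for this fall.

The compounds shown leave open whether the fall belongs to methyl in particular or would also appear with another group at that place, such as a chlorine atom, a methoxy group, an amine or a carboxylic acid. They also leave open whether a single group at this place, with hydrogen at the other, would give a number like that of compound 3 or like that of compound 2.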